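This account rests on a few compounds, and the source may have more. Where it says the series, first, only, none or still open, it means among the compounds named here.

Measured in a functional assay on PC-3 cells (Homo sapiens) for inhibition, read by MTT assay, with a stated time of 48 h; a lower number here means a stronger inhibitor of growth, a higher number a weaker inhibitor of growth:
- compound 1 `CN1CC[C@H](c2c(O)cc(O)c3c(=O)cc(/C=C/c4ccccc4)oc23)[C@H](O)C1`: 58000 nM
- compound 2 `CN1CC[C@H](c2c(O)cc(O)c3c(=O)cc(/C=C/c4cccc(Cl)c4)oc23)[C@H](O)C1`: 10000 nM
- compound 3 `CN1CC[C@H](c2c(O)cc(O)c3c(=O)cc(/C=C/c4ccccc4F)oc23)[C@H](O)C1`: 20000 nM

Two steps place compound 3 on these numbers. The data show a 2.9-fold lower number from compound 1 to compound 3 (0.46 log units; beyond the scatter), a real gain, and also a 2.0-fold higher number from compound 2 to compound 3 (0.30 log units; within the scatter), so it cannot be told apart from compound 2.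

Compound 4 `CN1CC[C@H](c2c(O)cc(O)c3c(=O)cc(/C=C/c4ccccc4Cl)oc23)[C@H](O)C1` has chloro in place of fluoro on an aromatic carbon, ortho to a large group: chloro in place of fluoro on an aromatic carbon.

For the measured compounds named here, no measured pair makes this exact swap, so the evidence is indirect. Chloro in place of hydrogen gave a 5.8-fold lower number from compound 1 to compound 2 (0.76 log units; beyond the scatter), and fluoro in place of hydrogen gave a 2.9-fold lower number from compound 1 to compound 3 (0.46 log units; beyond the scatter). Both steps lowered the number, and the chloro step was somewhat larger. However, the chloro of compound 2 sits on a 3-chlorophenyl group, not a 2-chlorophenyl group. A small drop, or none beyond the scatter, therefore seems likely. The expected step is a 1.5-fold lower number from compound 3 to compound 4 (0.19 log units; within the scatter).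

For compound 4 the estimated value is 13000 nM, with an expected range of 5000 nM to 32000 nM.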

Compound 4, concentration for 50% growth inhibition: 17000 nM
Compound 4: middle estimate off by 1.3-fold (0.12 log units), on the low side; the range from low to high includes it.
By their numbers in this assay, from the lowest: compounds 2, 4 and 3 (each within the scatter of the next); then compound 1.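

Chloro and fluoro at this place, ortho to a large group, cannot be told apart (a 1.2-fold lower number from compound 3 to compound 4 (0.07 log units; within the scatter)), and 2-chlorophenyl cannot be told apart from 3-chlorophenyl either (a 1.7-fold higher number from compound 2 to compound 4 (0.23 log units; within the scatter)). Chloro in place of hydrogen at this place still gives a real but modest gain (a 3.4-fold lower number from compound 1 to compound 4 (0.53 log units; beyond the scatter)), so all three halogen-bearing compounds now stand below compound 1, with none going against this, while the identity of the halogen and the two chlorine places shown make no readable difference. Nothing measured here accounts for these results.

From the compounds shown here alone, whether a methoxy group, a nitrile or an amine on this ring would behave like the halogens remains open. So does whether any change on this ring could lower the number much further than these modest steps.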